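This account rests on a few compounds, and the source may have more. Where it says the series, first, only, none or still open, it means among the compounds named here.

Working notes on the series. In a functional assay on MGC-803 cells (Homo sapiens) for inhibition, read by MTT assay, with a stated time of 72 h (on this read-out higher numbers stand for weaker inhibition and lower numbers for stronger inhibition), compound 2 (`O=C(Nc1cccc(F)c1)C1CCN(C/C=C/c2ccccc2)CC1`) gives 23300 nM and compound 1 (`COc1cccc(NC(=O)C2CCN(C/C=C/c3ccccc3)CC2)c1`) gives 37200 nM. With only these two measurements, the two values lie within the scatter of each other, so neither compound can be separated from the other on this read-out.

The next compound is compound 3 (`O=C(Nc1cccc(Cl)c1)C1CCN(C/C=C/c2ccccc2)CC1`), which has chloro in place of fluoro on an aromatic carbon, meta to a large group: chloro in place of fluoro on an aromatic carbon. The rest of the structure is shared with compound 2.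

Going by the values given here, only one measured step bears on this change, the exchange of fluoro in place of methoxy on an aromatic carbon, which gave a 1.6-fold lower number from compound 1 to compound 2 (0.20 log units; within the scatter). Among the compounds with values here, no measured compound carries chloro, so this single step is only a loose guide. As that exchange stayed within the scatter, no step beyond the scatter is expected in this assay for the smaller exchange of one halogen for another, and no direction can be called with confidence. The expected change is a 1.2-fold lower number from compound 2 to compound 3 (0.07 log units; within the scatter). For compound 3 the estimated value is 20000 nM, with an expected range of 9000 nM to 42000 nM.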

Compound 3, half-maximal inhibitory concentration: 11300 nM
The estimate for compound 3 lay 1.8-fold (0.25 log units) above the measured number, and the stated range covers the measured number.
By their numbers in this assay, from the lowest: compound 3; then compounds 2 and 1 (each within the scatter of the next).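

In this assay this position now yields steps that clear the scatter: on the aromatic carbon, meta to a large group, chloro in place of fluoro gives a 2.1-fold lower number from compound 2 to compound 3 (0.31 log units; beyond the scatter) and chloro in place of methoxy gives a 3.3-fold lower number from compound 1 to compound 3 (0.52 log units; beyond the scatter) in a modest shift. The fluoro and methoxy pair could not separate anything at this place, whereas compound 3 stands apart from both other compounds and has the lowest number of the three, so the group on this carbon can move the read-out and chloro is the one group shown to do so. No measurement on hand gives a reason for the difference between chloro and the other two groups.

With only fluoro, chloro and methoxy at this place, the compounds shown do not tell whether the lower number is particular to chloro or would continue with bromo, trifluoromethyl or an amine. They also leave open how chloro would behave on another carbon of the same ring, and whether the step would hold with any change elsewhere in the shared core.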